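Iodo for tert-butyl on a second core

The compounds below may be only part of what the source reports. "The series", "measured", "known", "first", "only" and "open" are said of these compounds alone.

Measured so far:
compound 1, `CC(C)(C)c1ccc(NC2=NCCO2)cc1`, gives 2400 nM in a functional assay on M21 cells (Homo sapiens) for inhibition, read by sulforhodamine B assay, with a stated time of 48 h; a higher number here means a weaker inhibitor of growth, a lower number a stronger inhibitor of growth
compound 2, `Ic1ccc(NC2=NCCO2)cc1`, gives 2000 nM in this assay
compound 3, `CC(C)(C)c1ccc(NC(=O)NC(=O)CCl)cc1`, gives 1100 nM in this assay

Compound 1 and compound 2 share one core; compound 3 carries another, and the difference between the two cores is not broken down here. Compound 2 differs from compound 1 by iodo in place of tert-butyl on an aromatic carbon, and that change gave a 1.2-fold lower number from compound 1 to compound 2 (0.08 log units; within the scatter). Compound 4, `O=C(CCl)NC(=O)Nc1ccc(I)cc1`, is not yet measured; it differs from compound 3 by iodo in place of tert-butyl on an aromatic carbon. This is the same kind of change, though the place differs: in compound 2 the iodo sits para to a group of 6 heavy atoms, in compound 4 para to a group of 8 heavy atoms. Because a 1.2-fold lower number from compound 1 to compound 2 (0.08 log units; within the scatter) stayed within the scatter, a similarly small step is expected, namely a 1.2-fold lower number from compound 3 to compound 4 (0.06 log units; within the scatter). Compound 4 is therefore estimated at 950 nM, between 400 nM and 2300 nM.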

Compound 4, concentration for 50% growth inhibition: 4200 nM
Compound 4: middle estimate off by 4.4-fold (0.65 log units), on the low side; the measured number lies above the stated range.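

In this assay, iodo in place of tert-butyl gave a 3.8-fold higher number from compound 3 to compound 4 (0.58 log units; beyond the scatter) and so meant weaker growth inhibition on this core, while on the core of compound 1 the same swap stayed within the scatter. A result on one core therefore did not predict the result on the other: the same change on two cores in this assay, a 1.2-fold lower number (0.08 log units; within the scatter) from compound 1 to compound 2 and a 3.8-fold higher number (0.58 log units; beyond the scatter) from compound 3 to compound 4, 4.6-fold (0.66 log units) apart, beyond the scatter of two such steps.

With a single pair on each core, this does not show why the two cores differ, or how often such a gap would appear in other pairs.

The compounds shown leave open whether bromo or methyl at this place would follow the iodo or the tert-butyl result on each core. From the compounds shown here alone, how an amine or a carboxylic acid there would behave also remains open.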